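Furan in Place of Fluorobenzyl on an Unreadable Series

The compounds below may be only part of what the source reports. "The series", "measured", "known", "first", "only" and "open" are said of these compounds alone.

Compound 3 `CCOC(=O)c1ccc(-c2nn(Cc3cccc(F)c3)c3ccccc23)cc1` belongs to a set of three compounds tested in a functional assay on cells (Platelet, Homo sapiens) for inhibition; on this read-out higher numbers stand for weaker inhibition and lower numbers for stronger inhibition. In this assay compound 3 gives > 10000 nM, which is a limit of the assay and not a number. Compound 1 `CCOC(=O)c1cccc(-c2n[nH]c3ccccc23)c1` gives > 10000 nM in this assay, also a limit. Compound 2 `CCOC(=O)c1ccc(-c2nn(Cc3ccccc3Cl)c3ccccc23)cc1` gives > 10000 nM in this assay, again a limit. Within the data shown here, the only step between measured compounds that differ in one place is a step that the two limits leave unreadable from compound 2 to compound 3, and since both of its ends are limits its size cannot be read. Compound 3 therefore stands together with all the others at the limit of > 10000 nM in this assay, at which 3 of the 3 values shown sit, with no measured value falling inside the readable range.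

The change to compound 4 `CCOC(=O)c1ccc(-c2nn(-c3ccco3)c3ccccc23)cc1` is furan-2-yl in place of 3-fluorobenzyl on an aromatic nitrogen. Among the measured compounds shown here, the one step on the same aromatic nitrogen is the unreadable one from compound 2 to compound 3, so nothing measured gives a direction or a size for the new change. With every measured compound sitting at the limit, compound 4 is expected to remain there as well, and the step from compound 3 to compound 4 is estimated as a step that the limit leaves unreadable from compound 3 to compound 4. Compound 4 is accordingly estimated at 15000 nM in this assay, with a range from 5000 nM to 50000 nM, most likely reported only as a limit.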

Compound 4, half-maximal inhibitory concentration: > 10000 nM
Compound 4: a limit, no number; the forecaster's own chance of this, stated with the estimate: 85%; the middle value is on the limit's open side.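

In this assay compound 4 gives > 10000 nM, which is a limit of the assay and not a number. Neither step to compound 4, from compound 3 or from compound 2, can be read: the limit of > 10000 nM in this assay, at which 4 of the 4 values shown sit.

The compounds shown leave open whether any group on this aromatic nitrogen brings inhibition into the readable range, and how furan-2-yl compares with 3-fluorobenzyl or 2-chlorobenzyl.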